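The compounds below may be only part of what the source reports. "The series", "measured", "known", "first", "only" and "open" are said of these compounds alone.

Compound 1 `CC(C)OC(=O)C(O)Cn1cnc2c(N)ncnc21`: in a functional assay on HeLa cells (Homo sapiens) for cytotoxicity (on this read-out higher numbers stand for lower toxicity in this test and lower numbers for higher toxicity in this test), compound 1 gives > 400 ug/mL, which is a limit of the assay and not a number.
Compound 2 `COCCOC(=O)C(O)Cn1cnc2c(N)ncnc21`: in this assay compound 2 gives > 400 ug/mL, again a limit of the assay and not a number.

Compound 2 therefore stands at the top of what this assay can report: the limit of > 400 ug/mL in this assay, at which 2 of the 2 values shown sit. For the measured compounds named here, the only measured step, a step that the two limits leave unreadable from compound 1 to compound 2, changes the ester group but its size cannot be read, since both ends are limits.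

Compound 3 `Nc1ncnc2c1ncn2CC(O)C(=O)OC1CCCCC1` carries a larger, ring-shaped ester group: cyclohexyl in place of 2-methoxyethyl on an oxygen next to a carbonyl group. Nothing measured here shows that a change on this oxygen shifts the read-out, and no shift beyond the scatter is expected. Compound 3 is therefore estimated to sit at 400 ug/mL, between 200 ug/mL and 800 ug/mL, most likely again as a limit. The step this estimate implies, a number no higher from compound 2 to compound 3 (the limit leaves the size open), is expected to be none beyond the scatter.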

Compound 3, minimum cytotoxic concentration: 100 ug/mL
For compound 3 the middle estimate is 4.0-fold (0.60 log units) above the measured one; measured number below the stated range.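

Changing the group on this oxygen can move the read-out after all. In this assay, cyclohexyl in place of 2-methoxyethyl brings an at least 4.0-fold lower number from compound 2 to compound 3 (0.60 log units; beyond the scatter), and cyclohexyl in place of isopropyl brings an at least 4.0-fold lower number from compound 1 to compound 3 (0.60 log units; beyond the scatter); a lower number here stands for higher toxicity in this test, so a group on an oxygen next to a carbonyl group does bear on the result. The true size of both steps stays open, since only compound 3 gives a real number and the other two compounds stop at a limit: the limit of > 400 ug/mL in this assay, at which 2 of the 3 values shown sit.

The three compounds cannot separate the effect of the ring from that of the larger number of carbons. A hexyl chain on the same oxygen would speak to that question, and a carboxylic acid in place of the ester would show what the ester itself adds.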